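The source may hold more compounds than are shown below. What is called first, only, known or untested is meant among the compounds shown, and "the series" means these compounds.

Measured compounds in this series:
- compound 1, `COc1ccc(-c2cc(NO)c(C(=O)NC3CCCCC3)c(=O)o2)cc1`: 13900 nM
- compound 2, `O=C(Nc1ccccc1)c1c(NO)cc(-c2cccs2)oc1=O`: > 20000 nM

Both values come from an ADME assay on Huh-7 cells (Homo sapiens) for cytotoxicity, with a stated time of 3 days; on this read-out lower numbers stand for higher toxicity in this test and higher numbers for lower toxicity in this test. Compound 1 gives 13900 nM in this assay. Compound 2 stands at a limit in this assay and not at a number: its value of > 20000 nM is the limit of the test, so where compound 2 truly lies beyond that is open. For the measured compounds named here, the two compounds differ in more than one place, so no single step between them can be read; the values show only that compound 1 lies below the limit and compound 2 at it, a point noted in the evidence (the limit of > 20000 nM in this assay, at which 1 of the 2 values shown sits).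

The next compound, compound 3, `COc1ccc(NC(=O)c2c(NO)cc(-c3cccs3)oc2=O)cc1`, is not yet measured in this assay. It differs from compound 2 by the change (methoxy in place of hydrogen on an aromatic carbon), that is, methoxy in place of hydrogen on an aromatic carbon, the same difference read one bond out being phenyl to 4-methoxyphenyl. Going by the values given here, no measured pair shows this change, so no size for the step can be taken from the data. Because compound 2 sits at the limit > 20000 nM, compound 3 is expected to stay in the same region, with a step from compound 2 to compound 3 of a step that the limit leaves unreadable from compound 2 to compound 3, meaning none beyond the scatter. Compound 3 is therefore estimated at 22000 nM, within a range of 9000 nM to 50000 nM.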

Compound 3, half-maximal cytotoxic concentration: > 20000 nM
Compound 3: a limit, no number; the forecaster's own chance of this, stated with the estimate: 65%; the middle value does not contradict the limit.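

Compound 2 and compound 3 both stand at a limit in this assay and not at a number, so no size can be read for methoxy in place of hydrogen on an aromatic carbon: the limit of > 20000 nM in this assay, at which 2 of the 3 values shown sit. The compounds shown leave open where compound 2 and compound 3 truly lie beyond that limit, and whether this change shifts the read-out at all.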